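Amide homologation from compound 1: liver microsome clearance notes

The compounds below may be only part of what the source reports. "The series", "measured", "known", "first", "only" and "open" are said of these compounds alone.

Compound 1 `CC(=O)N[C@@H]1CCCc2c1cncc2N1C(=O)c2ccc(Cl)cc2[C@H]1C`: < 3.5 mL/min/kg (a limit)
Compound 2 `O=C1c2cc(F)c(Cl)cc2CCN1c1cccnc1`: < 3.5 mL/min/kg (a limit)
Compound 3 `CC1c2cc(Cl)ccc2C(=O)N1c1cccnc1`: 12.2 mL/min/kg

The read-out is an ADME assay on microsomes from liver (Homo sapiens) for metabolic stability, read by LC-MS, using NADPH, with stated times of 10 min and 30 min; a higher number here means faster removal of the compound, a lower number slower removal. In this assay compound 1 returns only a limit, < 3.5 mL/min/kg, and no number. Compound 2 likewise returns only a limit, < 3.5 mL/min/kg. Compound 3 gives a measured value, 12.2 mL/min/kg. Among the compounds with values here, the two limits sit at the limit of < 3.5 mL/min/kg in this assay, at which 2 of the 3 values shown sit, so compound 1 is among the slower-cleared members of this small set, while compound 3 is the one compound with a number above that limit.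

Compound 4 `CCC(=O)N[C@@H]1CCCc2c1cncc2N1C(=O)c2ccc(Cl)cc2[C@H]1C` is not yet measured in this assay. It differs from compound 1 by methyl in place of hydrogen on a saturated chain carbon bound to a carbonyl carbon, that is, acetyl to propanoyl on the amide chain. Within the data shown here, no step between measured compounds of this kind is available, so the expectation rests on the standing of compound 1 alone, whose value is only a limit.

The step from compound 1 to compound 4 is expected to be small, an at least 1.2-fold higher number from compound 1 to compound 4 (0.10 log units; that floor lies within the scatter), and not beyond the scatter of the assay. For compound 4 the clearance in this assay is estimated at 4.5 mL/min/kg, with a range from 2 mL/min/kg to 10 mL/min/kg, and there is a fair chance that it again comes back only as a limit.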

Compound 4, clearance: < 3.5 mL/min/kg
Compound 4: no number, only a limit (the forecaster's own chance of this, stated with the estimate: 45%); at least 1.2-fold (0.10 log units) between middle value and limit.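

In this assay compound 1 and compound 4 each return only a limit, so no step can be read for the change from acetyl to propanoyl: the limit of < 3.5 mL/min/kg in this assay, at which 3 of the 4 values shown sit. The compounds shown leave open what the actual clearance of compound 1 and compound 4 is, and so whether this change alters it at all.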